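Swapping a nitrophenyl for a methylphenyl on a cinnamoyl hydrazide

The source may hold more compounds than are shown below. What is called first, only, known or untested is meant among the compounds shown, and "the series" means these compounds.

Of the compounds shown here, three sharing one core have been measured in a functional assay on cells (Cancer cell lines, Homo sapiens) for inhibition, read by MTT assay, with a stated time of 48 h; a lower number here means a stronger inhibitor, a higher number a weaker inhibitor. Compound 1 `O=C(/C=C/c1ccccc1Br)NNC(=O)c1ccc2c(c1)OCCO2` gives 2110 nM. Compound 2 `O=C(/C=C/c1cccc([N+](=O)[O-])c1)NNC(=O)c1ccc2c(c1)OCCO2` gives 1560 nM. Compound 3 `Cc1cccc(/C=C/C(=O)NNC(=O)c2ccc3c(c2)OCCO3)c1` gives 2890 nM. Compound 2 has the lowest of these three numbers, yet its steps to the other two, a 1.4-fold lower number from compound 1 to compound 2 (0.13 log units; within the scatter) and a 1.9-fold higher number from compound 2 to compound 3 (0.27 log units; within the scatter), both stay within the scatter, so no real order among them can be claimed.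

Compound 4 `Cc1ccccc1/C=C/C(=O)NNC(=O)c1ccc2c(c1)OCCO2` has not yet been measured. It differs from compound 2 in one place: 2-methylphenyl in place of 3-nitrophenyl on a double-bonded chain carbon bound to a double-bonded chain carbon. Within the data shown here, the steps that bear on this change are a 1.9-fold higher number from compound 2 to compound 3 (0.27 log units; within the scatter), where nitro gave way to methyl, and a 1.4-fold higher number from compound 1 to compound 3 (0.14 log units; within the scatter), where a different ring substituent and position were exchanged; both stayed within the scatter. Accordingly, in this assay a step of a 1.7-fold higher number from compound 2 to compound 4 (0.22 log units; within the scatter) is expected, most likely not beyond the scatter. For compound 4 the estimate is 2600 nM, with a range from 1200 nM to 5500 nM.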

Compound 4, half-maximal inhibitory concentration: 7710 nM
Beside the measured number, compound 4's estimate is 3.0-fold (0.47 log units) below it; the whole stated range lies below it.
By their numbers in this assay, from the lowest: compounds 2, 1 and 3 (each within the scatter of the next); then compound 4.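

At the place on a double-bonded chain carbon bound to a double-bonded chain carbon, the earlier exchanges all stayed within the scatter in this assay, but 2-methylphenyl in place of 3-nitrophenyl gives a 4.9-fold higher number from compound 2 to compound 4 (0.69 log units; beyond the scatter) and so shows that this place can respond to a change of group. The position of the methyl on the ring matters too, as 2-methylphenyl in place of 3-methylphenyl gives a 2.7-fold higher number from compound 3 to compound 4 (0.43 log units; beyond the scatter) with no change in the atoms of the group. The identity of the group also counts, as methyl in place of bromo gives a 3.7-fold higher number from compound 1 to compound 4 (0.56 log units; beyond the scatter) and the two are therefore not interchangeable here.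

From the compounds shown here alone, how an aminophenyl group or a phenyl group carrying a carboxylic acid would fare at this place remains open. Nothing measured here bears on why these steps arise.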